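Carbonyl substituent changes at the furanyl dihydropyrimidinone core

A few compounds are considered here, and "the series" means these few. Any claim that something is new, unique, unknown or untested is made for them only; others in the source may bear on it.

Measured so far in an assay on membranes from CHO cells for displacement of a labelled ligand from adenosine receptor A1 (Homo sapiens), read by scintillation counting, with a stated time of 60 min, tested at 1 uM; a lower number here means less inhibition, a higher number more inhibition at the concentration tested (going by the name of the read-out):
compound 1, `CCCOC(=O)C1=C(C)NC(=O)NC1c1ccoc1`: 50%
compound 2, `CC1=C(C(=O)OC(C)(C)C)C(c2ccoc2)NC(=O)N1`: 11%
compound 3, `CCN(CC)C(=O)C1=C(C)NC(=O)NC1c1ccoc1`: 15%

Compound 3 holds the second highest of the three numbers. Its nearest neighbour is compound 2, with a number 4 percentage points higher from compound 2 to compound 3 (within the scatter); the furthest step is a number 35 percentage points lower from compound 1 to compound 3 (beyond the scatter), a large step. The change to compound 4, `CCSC(=O)C1=C(C)NC(=O)NC1c1ccoc1`, is ethylsulfanyl in place of diethylamino on a carbonyl carbon. Within the data shown here, the steps that bear on it are both exchanges at the same carbonyl carbon: a number 35 percentage points lower from compound 1 to compound 3 (beyond the scatter) and a number 4 percentage points higher from compound 2 to compound 3 (within the scatter), showing that the oxygen-linked propyl in compound 1 stands well above the other two variants. Among the measured compounds shown here, no measured step uses a sulfur link, so the direction is uncertain; a moderate rise is expected, a number 20 percentage points higher from compound 3 to compound 4 (beyond the scatter). Compound 4 is estimated at 35%, between 10% and 60%.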

Compound 4, a percentage reported as inhibition, at one concentration (the size of the read-out at that concentration, not a potency): 3%
Compound 4: the middle estimate sits 32 percentage points above what was measured; the measured number lies below the stated range.
By their numbers in this assay, from the lowest: compounds 4, 2 and 3 (each within the scatter of the next, the first and the last beyond it); then compound 1.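

In this assay, the sulfur link on this carbonyl carbon does not hold the level of propoxy: a number 47 percentage points lower from compound 1 to compound 4 (beyond the scatter), and a number 12 percentage points lower from compound 3 to compound 4 (beyond the scatter). Against tert-butoxy, a number 8 percentage points lower from compound 2 to compound 4 (within the scatter), so among the four variants only compound 1 stands apart from the rest, and ethylsulfanyl adds a modest drop from diethylamino. No evidence on hand accounts for these differences.

Going by these compounds, whether the low number of compound 4 goes with the sulfur link or with the ethyl chain remains open. Propylsulfanyl or ethoxy on this carbonyl carbon would separate the two.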